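Swapping the aryl substituent: from methyl to nitro

The source may report more compounds than this note shows. Statements on the series, on what has been measured and on what is new or still open speak of the compounds shown alone.

Measured compounds:
Compound 1, `CC1CC/C(=N\Nc2cccc(Br)c2)c2ncc(C(=O)O)c(=O)n21`, gives 0.4 umol/kg in a functional assay on the whole organism for inhibition, with Rattus norvegicus as the target; a lower number here means that less compound is needed, a higher number that more compound is needed for the effect.
Compound 2, `Cc1cccc(N/N=C2\CCC(C)n3c2ncc(C(=O)O)c3=O)c1`, gives 0.4 umol/kg in this assay.

Compound 2 is level with compound 1 in this assay; the difference between the two readings is within the scatter of repeated measurements, so neither can be called more or less active. Among the compounds with values here, the one measured step, no change at the digits printed from compound 1 to compound 2 (within the scatter), shows that exchanging bromo for methyl on the aromatic carbon left the dose needed for half-maximal inhibition unchanged.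

Compound 3, `CC1CC/C(=N\Nc2cccc([N+](=O)[O-])c2)c2ncc(C(=O)O)c(=O)n21`, is not yet measured. It differs from compound 2 in one place: nitro in place of methyl on an aromatic carbon. Within the data shown here, no measured step covers a methyl-to-nitro exchange, so the only guidance is the bromo-to-methyl step between compound 1 and compound 2, which was flat. Two rather different groups at this carbon gave the same reading; a third group is therefore expected to land near the same value, with a small allowance for a higher dose. The step from compound 2 to compound 3 in this assay is estimated as a 1.5-fold higher number from compound 2 to compound 3 (0.18 log units; within the scatter). Compound 3 is expected to give about 0.6 umol/kg in this assay, within a range from 0.2 umol/kg to 2 umol/kg.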

Compound 3, dose for 50% inhibition: 0.5 umol/kg
The estimate for compound 3 lay 1.2-fold (0.08 log units) above the measured number; low and high end bracket the measured number.
By their numbers in this assay, from the lowest: compounds 1, 2 and 3 (each within the scatter of the next).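

In this assay, putting nitro in place of methyl gives a 1.3-fold higher number from compound 2 to compound 3 (0.10 log units; within the scatter), and putting nitro in place of bromo gives a 1.3-fold higher number from compound 1 to compound 3 (0.10 log units; within the scatter). Until now this aromatic carbon had been seen carrying only bromo and methyl, so the flat result could have been limited to that pair; nitro has more heavy atoms than methyl and brings hydrogen-bond acceptors that methyl lacks, yet the readings stay level. Across these three compounds, then, the dose needed for the effect in the whole animal does not separate the three groups, and none of the three goes against that.

From the compounds shown here alone, whether the same holds for an amine, a carboxylic acid or a longer chain on this carbon, or for any of these groups on another carbon of the same ring, remains open. No measurement is at hand that would explain why the three readings sit together, so the level result stands as an observation only.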